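The compounds below may be only part of what the source reports. "The series", "measured", "known", "first", "only" and "open" are said of these compounds alone.

The three compounds measured in a functional assay on HPAC cells (Homo sapiens) for inhibition, read by MTT assay, with a stated time of 72 h; on this read-out lower numbers stand for stronger inhibition of growth and higher numbers for weaker inhibition of growth:

Compound 1, `O=S(=O)(NCCCNCc1ccc(Cl)cc1)c1cc(C(F)(F)F)cc(C(F)(F)F)c1`, gives 2800 nM.
Compound 2, `CC(C)(C)c1ccc(CNCCCNS(=O)(=O)c2cc(C(F)(F)F)cc(C(F)(F)F)c2)cc1`, gives 2300 nM.
Compound 3, `O=S(=O)(NCCCNCc1ccc(C(F)(F)F)cc1)c1cc(C(F)(F)F)cc(C(F)(F)F)c1`, gives 2700 nM.

These three share one core and differ only in the group on the far aromatic ring. Going by the values given here, compound 3 stands among them at a number almost the same as that of compound 1, as a 1.0-fold lower number from compound 1 to compound 3 (0.02 log units; within the scatter) shows, and the step of a 1.2-fold higher number from compound 2 to compound 3 (0.07 log units; within the scatter) is likewise within the scatter, so no compound of the three can be called stronger or weaker than another.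

Compound 4, `O=S(=O)(NCCCNCc1ccc(-c2ccccc2)cc1)c1cc(C(F)(F)F)cc(C(F)(F)F)c1`, is the next step from compound 3: phenyl in place of trifluoromethyl on an aromatic carbon. Among the compounds with values here, every measured step so far has swapped the group at this same place on the ring, and none of them, a 1.2-fold lower number from compound 1 to compound 2 (0.09 log units; within the scatter), a 1.0-fold lower number from compound 1 to compound 3 (0.02 log units; within the scatter) or a 1.2-fold higher number from compound 2 to compound 3 (0.07 log units; within the scatter), moved the number beyond the scatter. On that basis the swap to phenyl is expected to change little in this assay; the estimated step is a 1.1-fold lower number from compound 3 to compound 4 (0.03 log units; within the scatter). Compound 4 is therefore expected to give about 2500 nM, within a range of 1200 nM to 5500 nM.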

Compound 4, concentration for 50% growth inhibition: 2700 nM
For compound 4 the middle estimate is 1.1-fold (0.03 log units) below the measured one, and the stated range covers the measured number.
By their numbers in this assay, from the lowest: compounds 2, 3, 4 and 1 (each within the scatter of the next).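

Phenyl brings a six-membered aromatic ring of carbon only where trifluoromethyl had no ring, with 6 heavy atoms in place of 4, yet in this assay the number stays within the scatter (no change at the digits printed from compound 3 to compound 4 (within the scatter)). The same holds when phenyl is compared with the other two groups, tert-butyl (a 1.2-fold higher number from compound 2 to compound 4 (0.07 log units; within the scatter)) and chloro (a 1.0-fold lower number from compound 1 to compound 4 (0.02 log units; within the scatter)), so at this position an added aromatic ring has made no readable difference to growth inhibition. Nothing measured here accounts for this flat response.

Going by these compounds, it remains open whether an amine or a carboxylic acid at this position would move the number beyond the scatter. Also open, on these data alone, is whether a change elsewhere in the shared core, such as a longer chain, would do so.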